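Naphthyl for trifluoromethylphenyl on the piperazine of an aminothiophene

The source may report more compounds than this note shows. Statements on the series, on what has been measured and on what is new or still open speak of the compounds shown alone.

Measured compounds:
compound 1, `Nc1scc(CN2CCN(c3cccc(Cl)c3Cl)CC2)c1C(=O)c1ccc(Cl)cc1`, 3.2%
compound 2, `Nc1scc(CN2CCN(c3cccc(C(F)(F)F)c3)CC2)c1C(=O)c1ccc(Cl)cc1`, -30%

Both were tested in a functional assay on CHO cells with adenosine receptor A1 (Homo sapiens) as the target, read by cAMP accumulation and immunoassay, with a stated time of 6 min, tested at 0.1 uM; on this read-out higher numbers stand for a weaker effect at the one concentration tested and lower numbers for a stronger effect. For the measured compounds named here, compound 1 gives 3.2%, and compound 2 gives -30%, the lowest of the two numbers, with compound 1 as its only neighbour. Going by the values given here, the single measured step, a number 33.2 percentage points lower from compound 1 to compound 2 (beyond the scatter), shows that exchanging the aryl group on the ring nitrogen can move the read-out a long way.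

Compound 3, `Nc1scc(CN2CCN(c3cccc4ccccc34)CC2)c1C(=O)c1ccc(Cl)cc1`, is not yet measured. It differs from compound 2 by naphthalen-1-yl in place of 3-(trifluoromethyl)phenyl on an amine nitrogen in a ring.

Among the compounds with values here, the one step that bears on this change is a number 33.2 percentage points lower from compound 1 to compound 2 (beyond the scatter), which concerns the same position and was large. It gives a direction only for the trifluoromethylphenyl against the dichlorophenyl, not for the naphthalenyl, so the size and sign of the new step are uncertain. The account expects a step of a number 20 percentage points higher from compound 2 to compound 3 (beyond the scatter), moving compound 3 back toward the number of compound 1, and estimates for compound 3 a value of -10%, within a range from -45% to 25%.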

Compound 3, a percentage reported as activity, at one concentration (the size of the read-out at that concentration, not a potency): 0%
Beside the measured number, compound 3's estimate is 10 percentage points below it, within the range that was stated.
By their numbers in this assay, from the lowest: compound 2; then compounds 3 and 1 (each within the scatter of the next).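

In this assay, the step of a number 30 percentage points higher from compound 2 to compound 3 (beyond the scatter) shows that the low number of compound 2 does not carry over to every aryl group on this amine nitrogen in a ring, even though the entering naphthalen-1-yl and the leaving 3-(trifluoromethyl)phenyl have the same count of heavy atoms. The step of a number 3.2 percentage points lower from compound 1 to compound 3 (within the scatter) adds what the earlier pair could not show: naphthalen-1-yl and 2,3-dichlorophenyl, which share no substituent atoms, give numbers that cannot be told apart on this read-out. Among these three compounds, 3-(trifluoromethyl)phenyl alone stands apart, with compound 2 beyond the scatter of both the others. Nothing given here accounts for these numbers. The compounds shown leave open how a plain phenyl or a pyridine ring on the same nitrogen would read, and whether a methoxy group in place of the trifluoromethyl would keep the low number of compound 2. Each compound also has a single reading at one concentration on one shared core, so the same separation of these aryl groups on a different core remains an open question.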